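Methyl for Phenyl on Nitrogen in Two Different Cores

The source may report more compounds than this note shows. Statements on the series, on what has been measured and on what is new or still open speak of the compounds shown alone.

Measured compounds:
compound 1, `CCOc1ccc(NC(=O)c2c(N)n[nH]c2NC)cc1`: 7900 nM
compound 2, `CCOc1ccc(NC(=O)c2c(N)n[nH]c2Nc2ccccc2)cc1`: 4470 nM
compound 3, `CCOc1ccc(NC(=O)/C(C#N)=C(\Nc2ccccc2)SC)cc1`: 20300 nM

Of the compounds shown here, three have been tested in a functional assay on CCRF-CEM cells (Homo sapiens) for cytotoxicity, read by resazurin assay, with a stated time of 48 h; a higher number here means a weaker inhibitor, a lower number a stronger inhibitor. Compound 2 carries an anilino group on its core; compound 1 differs from it by methyl in place of phenyl on a nitrogen on an aromatic ring. The step between them, a 1.8-fold higher number from compound 2 to compound 1 (0.25 log units; within the scatter), is small and within the usual scatter, so the two numbers cannot be ordered.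

Compound 3 is built on another core. The difference between the two cores is not broken down here. In this assay compound 3 gives 20300 nM, the highest of the three numbers, and its gaps to compound 1 and compound 2 are both beyond the scatter.

Compound 4, `CCOc1ccc(NC(=O)/C(C#N)=C(\NC)SC)cc1`, has not yet been measured in this assay. It differs from compound 3 by methyl in place of phenyl on an amine nitrogen. This is the same kind of change as from compound 2 to compound 1, but not the same: there the nitrogen sits on an aromatic ring with an aromatic carbon as its other neighbour, while here it is an amine nitrogen whose other neighbour is a double-bonded chain carbon.

The expected step is a 1.4-fold higher number from compound 3 to compound 4 (0.14 log units; within the scatter), which rests on the small step of a 1.8-fold higher number from compound 2 to compound 1 (0.25 log units; within the scatter) seen with the same kind of change. Compound 4 is therefore expected to give about 28000 nM in this assay, with a likely range from 9000 nM to 90000 nM.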

Compound 4, half-maximal inhibitory concentration: 9940 nM
Compound 4: the middle estimate sits 2.8-fold (0.45 log units) above what was measured; measured number inside the range.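

In this assay, methyl in place of phenyl on an amine nitrogen gives a 2.0-fold lower number from compound 3 to compound 4 (0.31 log units; beyond the scatter), a modest step. Set beside the same kind of change on the other core, this result shows that the size of the step does not carry over unchanged from one core to the other in this series: the same change on two cores in this assay, a 1.8-fold higher number (0.25 log units; within the scatter) from compound 2 to compound 1 and a 2.0-fold lower number (0.31 log units; beyond the scatter) from compound 3 to compound 4, 3.6-fold (0.56 log units) apart, beyond the scatter of two such steps

With a single pair on each core, this shows only that the outcome of the change differed between these two pairs; it gives no reason for the difference, does not tell which part of the cores matters, and, with the step on the core of compound 1 within the scatter, does not show that the change works in opposite directions on the two cores.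

The compounds shown carry only phenyl or methyl on this nitrogen, so it stays open how an ethyl group, a longer chain or a benzyl group would read on either core. As far as these compounds go, it also stays open whether further pairs on these two cores, or the same exchange on a third core, would keep the two steps as far apart as these pairs do.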